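Compound 4: a trifluoromethyl isomer of compound 3

The compounds below may be only part of what the source reports. "The series", "measured", "known", "first", "only" and "open" are said of these compounds alone.

Measured in a functional assay on CWR22R cells (Homo sapiens) for antiproliferative activity, read by propidium iodide staining, with a stated time of 96 h (a higher number here means a weaker inhibitor, a lower number a stronger inhibitor), so far:
- compound 1 `CC(O)(CSc1ccc(F)cc1)C(=O)Nc1ccc(S(F)(F)(F)(F)F)cc1` (13500 nM)
- compound 2 `CC(O)(CSc1ccc(C(F)(F)F)cc1)C(=O)Nc1ccc(S(F)(F)(F)(F)F)cc1` (14800 nM)
- compound 3 `CC(O)(CSc1cccc(C(F)(F)F)c1)C(=O)Nc1ccc(S(F)(F)(F)(F)F)cc1` (23400 nM)

Compound 3 gives 23400 nM and sits within the scatter of the other two compounds, as the steps show (a 1.7-fold higher number from compound 1 to compound 3 (0.24 log units; within the scatter); a 1.6-fold higher number from compound 2 to compound 3 (0.20 log units; within the scatter)). Compound 4 `CC(O)(CSc1ccccc1C(F)(F)F)C(=O)Nc1ccc(S(F)(F)(F)(F)F)cc1` carries 2-(trifluoromethyl)phenyl in place of 3-(trifluoromethyl)phenyl on a sulfur whose other neighbour is a saturated chain carbon (2-(trifluoromethyl)phenyl in place of 3-(trifluoromethyl)phenyl on a sulfur). The closest measured change is the exchange of 4-(trifluoromethyl)phenyl for 3-(trifluoromethyl)phenyl (a 1.6-fold higher number from compound 2 to compound 3 (0.20 log units; within the scatter)), which stayed within the scatter. So did the exchange of fluoro for trifluoromethyl (a 1.1-fold higher number from compound 1 to compound 2 (0.04 log units; within the scatter)). For the measured compounds named here, no measured compound carries the 2-(trifluoromethyl)phenyl group, so these steps are only indirect guidance. On this basis, no step beyond the scatter is expected in this assay, and the expected step is small (a 1.2-fold lower number from compound 3 to compound 4 (0.09 log units; within the scatter)). For compound 4 the estimated value is 19000 nM, with an expected range from 9000 nM to 40000 nM.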

Compound 4, half-maximal inhibitory concentration: 13200 nM
Compound 4: the middle estimate sits 1.4-fold (0.16 log units) above what was measured, within the range that was stated.
By their numbers in this assay, from the lowest: compounds 4, 1, 2 and 3 (each within the scatter of the next).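

Placing the trifluoromethyl group as 2-(trifluoromethyl)phenyl on the sulfur gives no step beyond the scatter in this assay, whether it replaces 3-(trifluoromethyl)phenyl (a 1.8-fold lower number from compound 3 to compound 4 (0.25 log units; within the scatter)) or 4-(trifluoromethyl)phenyl (a 1.1-fold lower number from compound 2 to compound 4 (0.05 log units; within the scatter)), so none of the three trifluoromethyl isomers separates from the others. The change from 4-fluorophenyl is equally small (a 1.0-fold lower number from compound 1 to compound 4 (0.01 log units; within the scatter)), and among these four compounds no aryl group shown on this sulfur stands apart. No measurement at hand offers a cause for these small differences.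

All four compounds keep a substituted phenyl on the sulfur and the same remaining core, so the range of this place is tested only narrowly. From the compounds shown here alone, it remains open whether a nitrile, an amine or a carboxylic acid on that phenyl, or a sulfone in place of the sulfur, would produce a step beyond the scatter.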